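The source may hold more compounds than are shown below. What is called first, only, known or untested is meant among the compounds shown, and "the series" means these compounds.

In an ADME assay on HFF cells (Homo sapiens) for cytotoxicity, with a stated time of 8 days (a higher number here means that more compound is tolerated, a lower number that less compound is tolerated), compound 1 `CSc1nc(N)nc2c1ncn2/C=C1/CC1(CO)CO` gives > 300000 nM, which is a limit and not a number. Compound 2 `CCCCSc1nc(N)nc2c1ncn2/C=C1/CC1(CO)CO` gives > 300000 nM, again a limit. The butyl chain of compound 2 replaces the shorter chain of compound 1, and the result is a step that the two limits leave unreadable from compound 1 to compound 2. Both measured compounds share a single ceiling: the limit of > 300000 nM in this assay, at which 2 of the 2 values shown sit. Compound 3 `CCCCNc1nc(N)nc2c1ncn2/C=C1/CC1(CO)CO` carries butylamino in place of butylsulfanyl on an aromatic carbon of the shared core, (butylamino in place of butylsulfanyl on an aromatic carbon). For the measured compounds named here, no measured compound shows what this exchange does, so the only guide is the limit of compound 2, > 300000 nM. A modest move toward less compound being tolerated is expected, though the result may again be a limit. The expected change is an at least 1.5-fold lower number from compound 2 to compound 3 (0.17 log units; that floor lies within the scatter). In this assay, compound 3 is estimated at 200000 nM, with an expected range from 60000 nM to 300000 nM.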

Compound 3, half-maximal cytotoxic concentration: > 300000 nM
Compound 3 was reported as a limit (the forecaster's own chance of this, stated with the estimate: 60%); middle value at least 1.5-fold (0.17 log units) from the limit.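

In this assay compound 3 gives > 300000 nM, a limit and not a number. No step among compound 1, compound 2 and compound 3 can be read, since all share one ceiling: the limit of > 300000 nM in this assay, at which 3 of the 3 values shown sit.

The compounds shown leave open whether the methylsulfanyl, butylsulfanyl and butylamino groups differ at all in how much compound is tolerated.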